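Swapping a Sulfur-Bearing Ring for a Methylpiperazine

This account rests on a few compounds, and the source may have more. Where it says the series, first, only, none or still open, it means among the compounds named here.

Among the compounds with values here, in a functional assay on MCF7 cells (Homo sapiens) for cytotoxicity, read by MTT assay, with a stated time of 24 h, tested at 16 ug/mL (on this read-out higher numbers stand for a stronger effect at the one concentration tested and lower numbers for a weaker effect), compound 1 `Cn1c(-c2ccc(NC(=O)CSc3nc4ccccc4o3)cc2)nc(-c2ccccc2)c1-c1ccccc1` gives 56%, while compound 2 `Cn1c(-c2ccc(NC(=O)CSC3=NCCS3)cc2)nc(-c2ccccc2)c1-c1ccccc1` gives 41.8%, the lower of the two numbers; the one measured step is a number 14.2 percentage points lower from compound 1 to compound 2 (beyond the scatter). Compound 3 `CN1CCN(CC(=O)Nc2ccc(-c3nc(-c4ccccc4)c(-c4ccccc4)n3C)cc2)CC1` differs from compound 2 by a group of 7 heavy atoms (5 carbon, 2 nitrogen; one six-membered non-aromatic ring with 2 hetero atoms) in place of a group of 6 heavy atoms (3 carbon, 1 nitrogen, 2 sulfur; one five-membered non-aromatic ring with 2 hetero atoms), on a saturated chain carbon bound to a carbonyl carbon. That measured step altered a group on a sulfur rather than on a saturated chain carbon bound to a carbonyl carbon, so it bears on this change only loosely, and it was modest. The expected step is therefore a number 1.8 percentage points lower from compound 2 to compound 3 (within the scatter), small and in no sure direction. Compound 3 is expected to give 40%, within 22% to 58%.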

Compound 3, a percentage reported as activity, at one concentration (the size of the read-out at that concentration, not a potency): 30.1%
The estimate for compound 3 lay 9.9 percentage points above the measured number; measured number inside the range.
By their numbers in this assay, from the lowest: compound 3; then compound 2; then compound 1.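

Placing 4-methylpiperazin-1-yl on the saturated chain carbon bound to a carbonyl carbon gives a number 11.7 percentage points lower from compound 2 to compound 3 (beyond the scatter) in this assay, and the same swap gives a number 25.9 percentage points lower from compound 1 to compound 3 (beyond the scatter) when it replaces (1,3-benzoxazol-2-yl)sulfanyl. The read-out at this place therefore also moves when the sulfur link itself is replaced, not only when the group on that sulfur changes. Nothing measured here explains either step. On these data alone, it remains open how a morpholine ring or a plain dimethylamino group would read on this same carbon.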